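The compounds below may be only part of what the source reports. "The series", "measured", "known", "first", "only" and "open" are said of these compounds alone.

Measured compounds in a functional assay on SH-SY5Y cells (Homo sapiens) for cytotoxicity, read by MTT assay, with stated times of 8 h, 30 min and 12 h, tested at 5 uM; on this read-out lower numbers stand for a weaker effect and higher numbers for a stronger effect at the one concentration tested:
compound 1, `N=C(NCc1ccc(O)cc1)[C@@H]1CCC(=O)N1Cc1ccc([N+](=O)[O-])cc1`, gives 34.5%
compound 2, `COc1ccc(CNC(=N)[C@@H]2CCC(=O)N2Cc2ccc([N+](=O)[O-])cc2)cc1`, gives 35.2%

Compound 2 stands highest of the two numbers, with compound 1 nearest at a number 0.7 percentage points higher from compound 1 to compound 2 (within the scatter), which is within the scatter. Compound 3, `COc1ccc(CNC(=N)[C@@H]2CCC(=O)N2Cc2ccc(C)cc2)cc1`, differs from compound 2 by methyl in place of nitro on an aromatic carbon. Going by the values given here, the one measured step, methyl in place of hydrogen on an oxygen on an aromatic ring, touches another part of the molecule and does not bear on this change. No step beyond the scatter is therefore expected in this assay, and the step from compound 2 to compound 3 is estimated at a number 1.2 percentage points lower from compound 2 to compound 3 (within the scatter). Compound 3 is expected to give 34%, with a range from 18% to 50%.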

Compound 3, a percentage reported as activity, at one concentration (the size of the read-out at that concentration, not a potency): 29.5%
Compound 3: middle estimate off by 4.5 percentage points, on the high side; measured number inside the range.
By their numbers in this assay, from the lowest: compounds 3, 1 and 2 (each within the scatter of the next).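

In this assay, the change from 4-nitrophenyl to 4-methylphenyl gives a number 5.7 percentage points lower from compound 2 to compound 3 (within the scatter). Going by these compounds alone, at this position, para to a large group, methyl can therefore stand in place of nitro without a step beyond the scatter, which the earlier compounds, differing only on the oxygen of the other aromatic ring, could not show. No evidence on the source of this small step is available.

As far as these compounds go, whether an amine, a carboxylic acid or a longer chain at this place would give a step beyond the scatter remains open. So does whether methyl in place of nitro reads the same with the free hydroxyl of compound 1.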